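A few compounds are considered here, and "the series" means these few. Any claim that something is new, unique, unknown or untested is made for them only; others in the source may bear on it.

Measured compounds:
Compound 1, `COc1ccc(OCCCON2C(N)=NC(N)=NC23CCOCC3)cc1`; in an assay on isolated protein for inhibition of Dihydrofolate reductase (Homo sapiens), read by spectrophotometry, using NADPH, with stated times of 5 s and 6 min (on this read-out lower numbers stand for stronger inhibition and higher numbers for weaker inhibition), compound 1 gives 11.1 nM.
Compound 2, `NC1=NC2(CCOCC2)N(OCCCOc2ccc(F)cc2)C(N)=N1`; in this assay compound 2 gives 46.6 nM.
Compound 3, `NC1=NC2(CCOCC2)N(OCCCOc2ccc(Cl)c(Cl)c2)C(N)=N1`; in this assay compound 3 gives 8.23 nM.

Compound 3 carries the lowest number of the three, but the nearest step is a 1.3-fold lower number from compound 1 to compound 3 (0.13 log units; within the scatter), so these two compounds cannot be ordered. Only compound 2 stands clearly apart, by a 5.7-fold lower number from compound 2 to compound 3 (0.75 log units; beyond the scatter), and compound 2 is also separated from compound 1 by a 4.2-fold higher number from compound 1 to compound 2 (0.62 log units; beyond the scatter).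

Compound 4, `NC1=NC2(CCOCC2)N(OCCCOc2cc(Cl)c(Cl)cc2Cl)C(N)=N1`, differs from compound 3 by chloro in place of hydrogen on an aromatic carbon. Within the data shown here, no measured step adds a chloro to a ring that already carries two chloro groups; the steps that reach the dichlorophenyl group from a single para substituent are the closest precedent, and the one within the shared pattern of a para group, compound 1 to compound 3, stays within the scatter. A further chloro is therefore expected to move the number little, if at all, in this assay. The expected step is a 1.2-fold lower number from compound 3 to compound 4 (0.07 log units; within the scatter). Compound 4 is estimated at 7 nM, within 3 nM to 16 nM.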

Compound 4, half-maximal inhibitory concentration: 36 nM
Compound 4: middle estimate off by 5.1-fold (0.71 log units), on the low side, outside the stated range (above it).
By their numbers in this assay, from the lowest: compounds 3 and 1 (each within the scatter of the next); then compounds 4 and 2 (each within the scatter of the next).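

In this assay, going from 3,4-dichlorophenyl to 2,4,5-trichlorophenyl is not a neutral change, with a 4.4-fold higher number from compound 3 to compound 4 (0.64 log units; beyond the scatter): a chloro on this carbon, ortho to a large group, raises the number, whereas the earlier change from 4-methoxyphenyl to 3,4-dichlorophenyl stayed within the scatter. Adding chlorine to the ring therefore does not by itself keep the number low, as a 3.2-fold higher number from compound 1 to compound 4 (0.51 log units; beyond the scatter) also places the trichloro compound on the weaker side, while a 1.3-fold lower number from compound 2 to compound 4 (0.11 log units; within the scatter) leaves it inseparable from the 4-fluorophenyl compound. Nothing available here bears on the cause of this step.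

From the compounds shown here alone, whether a methyl or a methoxy group on the same carbon would give a similar step remains open. Going by these compounds, it is also open whether a chloro there raises the number on a ring lacking the 3,4-dichloro pattern.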